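The compounds below may be only part of what the source reports. "The series", "measured", "known", "first", "only" and "open" are said of these compounds alone.

Of the compounds shown here, three sharing one core have been measured in a functional assay on L1210 cells (Mus musculus) for inhibition, read by MTT assay; on this read-out lower numbers stand for stronger inhibition and higher numbers for weaker inhibition. Compound 1 `CCOC(=O)c1ccc(NC(=O)N2CC2C#N)cc1` gives 9700 nM, compound 2 `N#CC1CN1C(=O)NCc1ccccc1` gives 3800 nM, and compound 3 `CCCCNC(=O)N1CC1C#N` gives 12000 nM. Of these three numbers compound 3 stands highest; its number and that of compound 1 lie within the scatter of each other, while compound 2 gives a number lower than that of compound 3 by more than the scatter. The next compound, compound 4 `CNC(=O)N1CC1C#N`, differs from compound 3 by hydrogen in place of propyl on a saturated chain carbon bound to an amide-type nitrogen. No step of this kind has been measured among these compounds, so nothing measured tells how it should play out. The step from compound 3 to compound 4 is expected to be small and, if anything, toward weaker inhibition: a 1.5-fold higher number from compound 3 to compound 4 (0.18 log units; within the scatter). Compound 4 is therefore estimated at 18000 nM, with a range from 8000 nM to 40000 nM.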

Compound 4, half-maximal inhibitory concentration: 8700 nM
For compound 4 the middle estimate is 2.1-fold (0.32 log units) above the measured one; measured number inside the range.
By their numbers in this assay, from the lowest: compound 2; then compounds 4, 1 and 3 (each within the scatter of the next).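

Replacing propyl with hydrogen on a saturated chain carbon bound to an amide-type nitrogen gives a 1.4-fold lower number from compound 3 to compound 4 (0.14 log units; within the scatter) in this assay. This first step measured at this position shows that butyl and methyl cannot be told apart here, since the change stays within the scatter. Nothing available explains this result. Going by these compounds, it remains open whether a longer chain would also stay within the scatter. On these data alone, it also remains open how a chain ending in an amine or a carboxylic acid would read in this assay.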